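The source may hold more compounds than are shown below. What is called first, only, known or untested is meant among the compounds shown, and "the series" means these compounds.

Three compounds sharing one core differ only in the aromatic group attached to a ring nitrogen. Compound 1 `O=C(Nc1ccc(Oc2ccnc3[nH]ccc23)cc1)c1cn(-c2ccc(F)cc2)c2ccccc2c1=O` carries a 4-fluorophenyl group there, and in a functional assay on MCF7 cells (Homo sapiens) for inhibition, read by MTT assay, with a stated time of 72 h (a lower number here means a stronger inhibitor, a higher number a weaker inhibitor), compound 1 gives 720 nM, the lowest number of the three. Compound 2 `O=C(Nc1ccc(Oc2ccnc3[nH]ccc23)cc1)c1cn(-c2ccc(Cl)cc2)c2ccccc2c1=O` gives 1590 nM, and compound 3 `O=C(Nc1ccc(Oc2ccnc3[nH]ccc23)cc1)c1cn(-c2ccc(C(F)(F)F)cc2Cl)c2ccccc2c1=O` gives 3570 nM. The step of a 2.2-fold higher number from compound 1 to compound 2 (0.34 log units; beyond the scatter) and the larger step of a 5.0-fold higher number from compound 1 to compound 3 (0.70 log units; beyond the scatter) both show that swapping or enlarging the halogen pattern on this ring raised the number.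

Compound 4 `O=C(Nc1ccc(Oc2ccnc3[nH]ccc23)cc1)c1cn(-c2ccc(F)c(Cl)c2)c2ccccc2c1=O` differs from compound 1 by chloro in place of hydrogen on an aromatic carbon. Because the measured steps of a 2.2-fold higher number from compound 1 to compound 2 (0.34 log units; beyond the scatter) and a 2.2-fold higher number from compound 2 to compound 3 (0.35 log units; beyond the scatter) each raised the number modestly when chlorine entered this ring, a comparable step is expected here, giving a 1.9-fold higher number from compound 1 to compound 4 (0.29 log units; within the scatter). Compound 4 is therefore estimated at 1400 nM, most likely between 600 nM and 3500 nM.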

Compound 4, half-maximal inhibitory concentration: 1510 nM
Compound 4: middle estimate off by 1.1-fold (0.03 log units), on the low side; the range from low to high includes it.
By their numbers in this assay, from the lowest: compound 1; then compounds 4 and 2 (each within the scatter of the next); then compound 3.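

Placing chloro on the 4-fluorophenyl ring, ortho to the fluoro group, raises the number in this assay (a 2.1-fold higher number from compound 1 to compound 4 (0.32 log units; beyond the scatter)), so this added atom alone is enough to lose ground against compound 1. With the chloro in this place, keeping the fluoro group leaves the result level with the 4-chlorophenyl group (a 1.1-fold lower number from compound 2 to compound 4 (0.02 log units; within the scatter)). The 3-chloro-4-fluorophenyl group still gives a lower number than the 2-chloro-4-(trifluoromethyl)phenyl group (a 2.4-fold lower number from compound 3 to compound 4 (0.37 log units; beyond the scatter)).

On these data alone, how an amine or a carboxylic acid on this ring would fare remains open. Nothing available explains these steps.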